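Swapping the amine ring on a kinase-type inhibitor scaffold

The source may hold more compounds than are shown below. What is called first, only, known or untested is meant among the compounds shown, and "the series" means these compounds.

Measured compounds:
- compound 1, `COc1cc2c(Oc3ccc(NC(=O)c4nn(-c5ccccc5C)c(=O)cc4C)cc3F)ccnc2cc1OCCCN1CCC(C)CC1`, 2240 nM
- compound 2, `COc1cc2c(Oc3ccc(NC(=O)c4nn(-c5ccccc5C(F)(F)F)c(=O)cc4C)cc3F)ccnc2cc1OCCCN1CCCC1`, 1010 nM
- compound 3, `COc1cc2c(Oc3ccc(NC(=O)c4nn(-c5cccc(F)c5)c(=O)cc4C)cc3F)ccnc2cc1OCCCN1CCCC1`, 1700 nM

All three share one core and were tested in a functional assay on U-87MG ATCC cells (Homo sapiens) for inhibition, read by MTT assay, with a stated time of 72 h; on this read-out higher numbers stand for weaker inhibition and lower numbers for stronger inhibition. Compound 3 gives 1700 nM, the second highest of the three numbers; its nearest neighbour is compound 1, and its furthest is compound 2, yet both gaps sit within the usual scatter, so none of the three can be called more or less potent than another. For the measured compounds named here, the one single-point step recorded, a 1.7-fold higher number from compound 2 to compound 3 (0.23 log units; within the scatter), concerns the aryl group and stays within the scatter.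

Compound 4, `COc1cc2c(Oc3ccc(NC(=O)c4nn(-c5cccc(F)c5)c(=O)cc4C)cc3F)ccnc2cc1OCCCN1CCC(C)CC1`, is reached from compound 3 by 4-methylpiperidin-1-yl in place of pyrrolidin-1-yl on a saturated chain carbon, three bonds along the chain from an oxygen on an aromatic ring. Going by the values given here, no measured step covers this particular change. Compound 1, which already carries the 4-methylpiperidin-1-yl ring, differs from compound 3 in two places, so its value only shows that this ring is compatible with a number close to that of compound 3. Among the compounds with values here, because compound 1 gives 2240 nM and the only recorded step, a 1.7-fold higher number from compound 2 to compound 3 (0.23 log units; within the scatter), is within the scatter, no shift beyond the scatter is expected in this assay. Compound 4 is therefore estimated at 1900 nM, with a range of 800 nM to 4500 nM, corresponding to an expected step of a 1.1-fold higher number from compound 3 to compound 4 (0.05 log units; within the scatter).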

Compound 4, half-maximal inhibitory concentration: 1800 nM
Compound 4: middle estimate off by 1.1-fold (0.02 log units), on the high side; low and high end bracket the measured number.
By their numbers in this assay, from the lowest: compounds 2, 3, 4 and 1 (each within the scatter of the next, the first and the last beyond it).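

In this assay, the amine ring at the end of the 3-carbon-linked chain can now be read as a single change: with the 3-fluorophenyl group held constant, a six-membered 4-methylpiperidin-1-yl ring in place of a five-membered pyrrolidin-1-yl ring gives a step that stays within the scatter (a 1.1-fold higher number from compound 3 to compound 4 (0.02 log units; within the scatter)). The new compound also provides a single-change comparison on the aromatic nitrogen with the 4-methylpiperidin-1-yl ring held constant, and 3-fluorophenyl in place of 2-methylphenyl likewise stays within the scatter (a 1.2-fold lower number from compound 1 to compound 4 (0.09 log units; within the scatter)). No accompanying measurement bears on why these numbers stay so close.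

Still open, as far as these compounds go, is whether an amine ring with a second hetero atom, such as morpholin-4-yl or 4-methylpiperazin-1-yl, or a shorter 2-(pyrrolidin-1-yl)ethyl chain would move the number beyond the scatter. Also open is whether the same ring swap would stay within the scatter with 2-(trifluoromethyl)phenyl on the aromatic nitrogen, as compound 2 has no 4-methylpiperidin-1-yl partner among the compounds shown.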